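A few compounds are considered here, and "the series" means these few. Any claim that something is new, unique, unknown or untested is made for them only; others in the source may bear on it.

In a functional assay on HCT-116 cells (Homo sapiens) for cytotoxicity, read by MTT assay (a higher number here means a weaker inhibitor, a lower number a stronger inhibitor), compound 1 `Cc1cc(O)c(C(=O)/C=C/c2ccccc2)c(=O)o1` gives > 100000 nM, a limit and not a number. Compound 2 `Cc1cc(O)c(C(=O)/C=C/c2ccccc2[N+](=O)[O-])c(=O)o1` gives > 100000 nM, also a limit. Compound 3 `COc1ccccc1/C=C/C(=O)c1c(O)cc(C)oc1=O` gives > 100000 nM, again a limit, so it has no readable value. For the measured compounds named here, the series so far stands at the limit of > 100000 nM in this assay, at which 3 of the 3 values shown sit. The next change is trifluoromethyl in place of methoxy on an aromatic carbon, which gives compound 4 `Cc1cc(O)c(C(=O)/C=C/c2ccccc2C(F)(F)F)c(=O)o1`. The measured steps that bear on it are a step that the two limits leave unreadable from compound 2 to compound 3, a step that the two limits leave unreadable from compound 1 to compound 3 and a step that the two limits leave unreadable from compound 1 to compound 2. None has a readable size, so none offers a size to carry over. No step beyond the scatter is expected in this assay, in either direction. The step expected is a number no higher from compound 3 to compound 4 (the limit leaves the size open). Compound 4 is estimated at 100000 nM, with an expected range from 30000 nM to 200000 nM.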

Compound 4, half-maximal inhibitory concentration: > 100000 nM
Compound 4 ended at the assay's limit (the forecaster's own chance of this, stated with the estimate: 85%); the middle value lies on the limit itself.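

Compound 4, like compound 1, compound 2 and compound 3, gives only a limit in this assay, so no step to compound 4 can be read: the limit of > 100000 nM in this assay, at which 4 of the 4 values shown sit.

The compounds shown leave open whether any change on the aromatic ring gives a readable value in this assay.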